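The source may hold more compounds than are shown below. What is called first, only, known or untested is meant among the compounds shown, and "the series" means these compounds.

Compound 1, `Cc1nnc(SCC(=O)c2ccccc2)n1N1C(=O)c2ccccc2C1=O`: in a functional assay on A549 cells (Homo sapiens) for cytotoxicity, read by MTT assay, with a stated time of 48 h (a lower number here means a stronger inhibitor, a higher number a weaker inhibitor), compound 1 gives only a limit, > 200000 nM.
Compound 2, `C#CCSc1nnc(C)n1N1C(=O)c2ccccc2C1=O`: in this assay compound 2 gives only a limit, > 200000 nM.
Compound 3, `C#CCSc1nnc(CC)n1N1C(=O)c2ccccc2C1=O`: in this assay compound 3 gives only a limit, > 200000 nM.

Compound 3 therefore stands at the edge of what this assay can report; no number is known for it, and the same holds for the two other compounds, since every value shown sits at the limit of > 200000 nM in this assay, at which 3 of the 3 values shown sit. Compound 4, `C=CCSc1nnc(CC)n1N1C(=O)c2ccccc2C1=O`, differs from compound 3 in one place: vinyl in place of ethynyl on a saturated chain carbon bound to a sulfur. Among the measured compounds shown here, two measured steps touch the same region of the molecule, the chain on the sulfur and the small group on the core. For the measured compounds named here, the first is a step that the two limits leave unreadable from compound 1 to compound 2, the second step that the two limits leave unreadable from compound 2 to compound 3. Neither can be read, because both ends of each step are limits. The measured steps thus give no sign that changes in this region move the read-out within the window of this assay. On that basis the expected step is a step that the limit leaves unreadable from compound 3 to compound 4, that is, none that could be seen. Compound 4 is accordingly estimated at 300000 nM, within a range from 100000 nM to 1000000 nM, and most likely it will again be reported only as a limit.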

Compound 4, half-maximal inhibitory concentration: > 200000 nM
Compound 4 was reported as a limit; the forecaster's own chance of this, stated with the estimate: 85%; the middle value does not contradict the limit.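

Among the compounds shown here, compound 3 and compound 4 both give only a limit rather than a number, so no step between them can be read: the limit of > 200000 nM in this assay, at which 4 of the 4 values shown sit.

The compounds shown leave open how strong any of them truly is in this assay and whether any change to the sulfur chain or the small core group would yield a measurable number.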